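The compounds below may be only part of what the source reports. "The series", "measured", "known", "first", "only" and "open" are said of these compounds alone.

Values in a functional assay on PLC-PRF-5 cells (Homo sapiens) for inhibition; on this read-out higher numbers stand for weaker inhibition and lower numbers for stronger inhibition:

compound 1 `Cc1cc(Oc2ccnc3c([N+](=O)[O-])cccc23)ccc1NC(=O)c1cc(C(F)(F)F)cc(C(F)(F)F)c1`: > 40000 nM (a limit of the assay)
compound 2 `Cc1cc(Oc2ccnc3c(N)cccc23)ccc1NC(=O)c1cc(C(F)(F)F)cc(C(F)(F)F)c1`: 25400 nM
compound 3 `O=C(Nc1cccc(Oc2ccnc3c([N+](=O)[O-])cccc23)c1)c1cc(C(F)(F)F)cc(C(F)(F)F)c1`: > 40000 nM (a limit of the assay)

The value of compound 1 in this assay is a limit, not a number. The value of compound 3 in this assay is likewise a limit; (the limit of > 40000 nM in this assay, at which 2 of the 3 values shown sit). How the cores of compound 1 and compound 3 differ is not broken down here.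

From compound 1 to compound 2 the change is amino in place of nitro on an aromatic carbon. This gives an at least 1.5-fold lower number from compound 1 to compound 2 (0.19 log units; that floor lies within the scatter).

Compound 4 `Nc1cccc2c(Oc3cccc(NC(=O)c4cc(C(F)(F)F)cc(C(F)(F)F)c4)c3)ccnc12` is not yet measured in this assay. It arises from compound 3 by amino in place of nitro on an aromatic carbon, the same change as that from compound 1 to compound 2.

The step is expected to be about an at least 1.1-fold lower number from compound 3 to compound 4 (0.05 log units; that floor lies within the scatter), resting on an at least 1.5-fold lower number from compound 1 to compound 2 (0.19 log units; that floor lies within the scatter) and on the limit for compound 3. Compound 4 is therefore expected near 35000 nM in this assay, between 12000 nM and 100000 nM, with a real chance that only a limit is reported again.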

Compound 4, half-maximal inhibitory concentration: 19000 nM
The estimate for compound 4 lay 1.8-fold (0.27 log units) above the measured number, and the stated range covers the measured number.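

In this assay, amino in place of nitro on an aromatic carbon gives an at least 2.1-fold lower number from compound 3 to compound 4 (0.32 log units; beyond the scatter), so on this core the change reads beyond the scatter. Across the two cores it points the same way, but this does not show that its size carries over: the same change on two cores in this assay, an at least 1.5-fold lower number (0.19 log units; that floor lies within the scatter) from compound 1 to compound 2 and an at least 2.1-fold lower number (0.32 log units; beyond the scatter) from compound 3 to compound 4; the limit leaves it open whether they differ. Compound 1 and compound 3, the two nitro compounds, each stand at a limit and not a number, so the true size of neither step is known: the limit of > 40000 nM in this assay, at which 2 of the 4 values shown sit.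

Open, going by these compounds, is how other groups on that aromatic carbon compare with amino, such as a dimethylamino group, an acetamide or a hydroxyl. Open too, on these data alone, is whether the change would hold on any core beyond these two.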